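This account rests on a few compounds, and the source may have more. Where it says the series, first, only, none or still open, it means among the compounds named here.

The measured compounds:
compound 1 `COc1ccc(-c2cn(Cc3ccc(F)cc3)c(=O)c(C(=O)NC3CCCCCC3)c2C)cc1`, 280 nM
compound 2 `COc1ccc(-c2cn(Cc3ccc(F)cc3)c(=O)c(C(=O)NC3CCCCCC3)c2-c2ccccc2)cc1`, > 10000 nM
compound 3 `Cc1c(-c2ccccc2)cn(Cc2ccc(F)cc2)c(=O)c1C(=O)NC1CCCCCC1`, "not determined" (no result reported)

Compound 1 `COc1ccc(-c2cn(Cc3ccc(F)cc3)c(=O)c(C(=O)NC3CCCCCC3)c2C)cc1` is measured in a functional assay on U-937 cells (Homo sapiens) for inhibition, read by scintillation counting, with a stated time of 15 min (on this read-out lower numbers stand for stronger inhibition and higher numbers for weaker inhibition), and gives 280 nM. Compound 2 `COc1ccc(-c2cn(Cc3ccc(F)cc3)c(=O)c(C(=O)NC3CCCCCC3)c2-c2ccccc2)cc1` gives > 10000 nM in this assay, and that value is a limit of the assay rather than a number. Going by the values given here, the one change between these two, (phenyl in place of methyl on an aromatic carbon), gives an at least 35-fold higher number from compound 1 to compound 2 (1.55 log units; beyond the scatter), a step that runs up to the limit of > 10000 nM in this assay, at which 1 of the 3 values shown sits.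

Compound 3 `Cc1c(-c2ccccc2)cn(Cc2ccc(F)cc2)c(=O)c1C(=O)NC1CCCCCC1` shows "not determined" (no result reported) in this assay, so no result is available for it. Its core differs from that of compound 1 by hydrogen in place of methoxy on an aromatic carbon. Compound 4 `O=C(NC1CCCCCC1)c1c(-c2ccccc2)c(-c2ccccc2)cn(Cc2ccc(F)cc2)c1=O` is not yet measured. It differs from compound 3 by phenyl in place of methyl on an aromatic carbon, the same kind of change as that from compound 1 to compound 2; the place differs in that it is ortho to a phenyl group (6 heavy atoms) rather than ortho to a 4-methoxyphenyl group (8 heavy atoms).

Because an at least 35-fold higher number from compound 1 to compound 2 (1.55 log units; beyond the scatter) was a large step that ended at a limit, the same kind of change is expected to weaken inhibition strongly in compound 4 as well. Compound 4 is therefore estimated at 15000 nM in this assay, with the range 3000 nM to 60000 nM, and it is expected that the assay may again report only a limit.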

Compound 4, half-maximal inhibitory concentration: > 10000 nM
Compound 4 ended at the assay's limit; the forecaster's own chance of this, stated with the estimate: 75%; the middle value lies beyond the limit too.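

In this assay compound 4 gives > 10000 nM, which is a limit and not a number. Compound 2 also stands at a limit, so no step can be read from compound 2 to compound 4, and the two share this value: the limit of > 10000 nM in this assay, at which 2 of the 4 values shown sit.

The compounds shown leave open what hydrogen in place of methoxy on an aromatic carbon does to inhibition, and how weak compound 2 and compound 4 really are.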